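Adding a second chloro to the core of compound 1

This account rests on a few compounds, and the source may have more. Where it says the series, first, only, none or still open, it means among the compounds named here.

Measured so far:
- compound 1 `ClCc1ccc(Cn2cnc3c(Cl)ncnc32)cc1`, 15900 nM
- compound 2 `ClCc1cccc(Cn2cnc3c(Cl)ncnc32)c1`, 6450 nM
- compound 3 `ClCc1ccc(Cn2cnc3nc(Cl)nc(Cl)c32)cc1`, 5750 nM

In a functional assay on MDA-MB-435 cells (Homo sapiens) for cytotoxicity, read by sulforhodamine B assay, with a stated time of 48 h (on this read-out lower numbers stand for higher toxicity in this test and higher numbers for lower toxicity in this test), compound 1 gives 15900 nM, the highest of the three numbers. Compound 2 gives 6450 nM and compound 3 gives 5750 nM; both of these lie beyond the scatter from compound 1, so compound 1 is the least toxic of the set in this assay. No pair of these compounds differs in only one place, so no single step can be read off among them.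

Compound 4 `ClCc1ccc(Cn2cnc3c(Cl)nc(Cl)nc32)cc1` is not yet measured. It differs from compound 1 in one place: chloro in place of hydrogen on an aromatic carbon between two ring nitrogen atoms of the fused core. Compound 3, which also carries two chloro groups on its fused core, gives 5750 nM, a lower number than compound 1, though its core is not the same. Among the compounds with values here, no step for this exact change is known, so the expectation rests on this loose comparison only.

Compound 4 is therefore expected to give a somewhat lower number than compound 1 in this assay, a step estimated at a 2.1-fold lower number from compound 1 to compound 4 (0.33 log units; beyond the scatter). The estimate for compound 4 is 7500 nM, with a range from 3000 nM to 19000 nM.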

Compound 4, concentration lethal to 50% of the cells: 50100 nM
Compound 4: the middle estimate sits 6.7-fold (0.82 log units) below what was measured; the whole stated range lies below it.
By their numbers in this assay, from the lowest: compounds 3 and 2 (each within the scatter of the next); then compound 1; then compound 4.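

Chloro in place of hydrogen on an aromatic carbon between two ring nitrogen atoms gives a 3.2-fold higher number from compound 1 to compound 4 (0.50 log units; beyond the scatter) in this assay and is the first single change in this set that can be read. A single added chlorine at this position is enough to move the number beyond the scatter, and the move is toward lower toxicity in this test. Nothing available explains this shift.

Only hydrogen and chloro are shown on this carbon, so it remains open whether the rise belongs to chloro alone or would also follow from another group there, such as an amine or a methoxy group. Going by these compounds, whether the same step would hold on compound 2 also remains open.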